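The source may hold more compounds than are shown below. What is called first, only, known or untested is meant among the compounds shown, and "the series" means these compounds.

Compound 1 `Cc1c(Cc2ccccc2S(=O)(=O)c2ccc(F)cc2)c2c(n1CC(=O)O)CCNC2=O` is the anchor of this pair. Within the data shown here, in a functional assay on CHO.K1 cells for antagonist activity at prostaglandin D2 receptor 2 (Homo sapiens), read by GTPgammaS binding, with a stated time of 1 h (on this read-out lower numbers stand for stronger inhibition and higher numbers for weaker inhibition), compound 1 gives 3.3 nM, the lowest of the two numbers measured so far. Compound 2 `Cc1c(Cc2ccccc2S(=O)(=O)N(C)Cc2ccccc2)c2c(n1CC(=O)O)CCNC2=O`, which keeps the sulfonyl sulfur and differs only in the group attached to it, gives 26 nM in this assay; the step from compound 1 to compound 2 is a 7.9-fold higher number from compound 1 to compound 2 (0.90 log units; beyond the scatter).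

Compound 3 `Cc1c(Cc2ccccc2C(O)c2ccccc2)c2c(n1CC(=O)O)CCNC2=O` has not yet been measured. It differs from compound 1 in one place: hydroxy(phenyl)methyl in place of (4-fluorophenyl)sulfonyl on an aromatic carbon. Among the measured compounds shown here, the only measured step that bears on this is the one from compound 1 to compound 2, where a change at the same sulfonyl sulfur, less extensive than the present one, already moved the number beyond the scatter. The present change removes the sulfonyl sulfur altogether, so a step in this assay of at least comparable size, toward a higher number, is expected, a 12-fold higher number from compound 1 to compound 3 (1.08 log units; beyond the scatter). Compound 3 is therefore estimated at 40 nM, with a range of 8 nM to 250 nM.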

Compound 3, half-maximal inhibitory concentration: 32 nM
The estimate for compound 3 lay 1.3-fold (0.10 log units) above the measured number; measured number inside the range.
By their numbers in this assay, from the lowest: compound 1; then compounds 2 and 3 (each within the scatter of the next).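

In this assay, hydroxy(phenyl)methyl in place of (4-fluorophenyl)sulfonyl on this aromatic carbon gives a 9.7-fold higher number from compound 1 to compound 3 (0.99 log units; beyond the scatter). The sulfonyl sulfur is therefore not needed for activity at this position, since compound 3 still gives 32 nM without it, though no replacement shown matches compound 1. The change swaps the sulfonyl for a hydroxy-bearing carbon and removes the fluorine in one step, and nothing shown assigns the step to either part or explains it.

Still open, on these data alone, is what the hydroxy group itself contributes, which a carbonyl or a plain methylene linker at the same place would test. Also open, as far as these compounds go, is whether a fluorine on the phenyl ring of hydroxy(phenyl)methyl would recover any of the difference from compound 1.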